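Microsome clearance: 3-chlorophenyl in place of 4-fluorophenyl

The source may report more compounds than this note shows. Statements on the series, on what has been measured and on what is new or still open speak of the compounds shown alone.

Measured compounds in an ADME assay on liver for metabolic stability, with Liver microsome (Homo sapiens) as the target, using microsomes; on this read-out higher numbers stand for fast clearance and lower numbers for slow clearance:
compound 1, `O=C(Nc1cc(-c2ccccn2)n[nH]1)N1CCC(c2ccc(Cl)cc2)CC1`, gives 30 mL.min-1.g-1
compound 3, `O=C(Nc1cc(-c2ccccn2)n[nH]1)N1CCC(c2ccc(F)cc2)CC1`, gives 42.5 mL.min-1.g-1
compound 2, `O=C(Nc1cc(-c2ccccn2)n[nH]1)N1CCC(Oc2ccccn2)CC1`, gives only a limit of the assay, < 11.9 mL.min-1.g-1

Compound 3 and compound 1 sit together at the upper end of the three values in this assay; the step between them, a 1.4-fold higher number from compound 1 to compound 3 (0.15 log units; within the scatter), is within the scatter, so no order between the two can be read. For the measured compounds named here, compound 2 is the one value sitting at the limit (the limit of < 11.9 mL.min-1.g-1 in this assay, at which 1 of the 3 values shown sits). The two steps that leave that limit are an at least 2.5-fold lower number from compound 1 to compound 2 (0.40 log units; beyond the scatter) and an at least 3.5-fold higher number from compound 2 to compound 3 (0.55 log units; beyond the scatter), both beyond the scatter.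

Compound 4, `O=C(Nc1cc(-c2ccccn2)n[nH]1)N1CCC(c2cccc(Cl)c2)CC1`, is not yet measured. The change from compound 3 is 3-chlorophenyl in place of 4-fluorophenyl on a saturated ring carbon. Going by the values given here, only one measured step concerns a change at the aromatic carbon, a 1.4-fold higher number from compound 1 to compound 3 (0.15 log units; within the scatter), and it is within the scatter. Among the compounds with values here, no measured step moves the halogen from one aromatic carbon to another, so the data give no direct guide to that part of the change. Given that, the step to compound 4 is expected to be a 1.2-fold lower number from compound 3 to compound 4 (0.08 log units; within the scatter), within the scatter. Compound 4 is therefore estimated at 35 mL.min-1.g-1 in this assay, with a range from 17 mL.min-1.g-1 to 72 mL.min-1.g-1.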

Compound 4, intrinsic clearance in microsomes: 30.8 mL.min-1.g-1
Compound 4: middle estimate off by 1.1-fold (0.06 log units), on the high side, within the range that was stated.
By their numbers in this assay, from the lowest: compounds 1, 4 and 3 (each within the scatter of the next). At a limit, below all of these: compound 2.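

For the compounds shown here, the first direct comparison of the two chlorophenyl groups at this saturated ring carbon in this assay is a 1.0-fold higher number from compound 1 to compound 4 (0.01 log units; within the scatter), and 3-chlorophenyl in place of 4-fluorophenyl gives a 1.4-fold lower number from compound 3 to compound 4 (0.14 log units; within the scatter), so neither the change of halogen nor the different chlorophenyl group can be read as an effect on this read-out. The contrast with the (pyridin-2-yl)oxy group, earlier seen for 4-chlorophenyl and 4-fluorophenyl, now extends to 3-chlorophenyl, with an at least 2.5-fold higher number from compound 2 to compound 4 (0.41 log units; beyond the scatter). Compound 2 remains a limit of the assay and not a number, so the full size of that step stays unknown: the limit of < 11.9 mL.min-1.g-1 in this assay, at which 1 of the 4 values shown sits.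

As far as these compounds go, it remains open whether the separation of compound 2 from the phenyl compounds goes with its oxygen link or with its pyridine ring, a question that a phenoxy group or a directly attached pyridin-2-yl group would address. From the compounds shown here alone, it is also open whether a non-halogen group on the phenyl ring, such as methoxy or a nitrile, would differ from compound 4 in this assay by more than the scatter.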